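Ring-amine substitution on the shared core

This account rests on a few compounds, and the source may have more. Where it says the series, first, only, none or still open, it means among the compounds named here.

Compound 1 `NC(=O)c1c(NC(=O)c2ccccc2Cl)sc2c1CCN(Cc1ccccc1Cl)C2` gives 2900 nM in a functional assay on HL-60 cells (Homo sapiens) for antiproliferative activity, with a stated time of 24 h (a lower number here means a stronger inhibitor, a higher number a weaker inhibitor), the lowest of the three numbers shown. Compound 2 `NC(=O)c1c(NC(=O)c2ccccc2F)sc2c1CCN(Cc1ccc(Cl)cc1Cl)C2` gives 13100 nM in this assay, and compound 3 `NC(=O)c1c(NC(=O)c2cccc([N+](=O)[O-])c2)sc2c1CCN(Cc1c(Cl)cccc1Cl)C2` gives 18400 nM. Both of these lie beyond the scatter from compound 1, so compound 1 is the strongest inhibitor among the measured compounds. Compound 4 `NC(=O)c1c(NC(=O)c2ccccc2Cl)sc2c1CCN(C(=S)Nc1ccccc1)C2` is not yet measured. It differs from compound 1 in one place: a group of 9 heavy atoms (7 carbon, 1 nitrogen, 1 sulfur; one six-membered aromatic ring of carbon only) in place of a group of 8 heavy atoms (7 carbon, 1 chlorine; one six-membered aromatic ring of carbon only), on an amine nitrogen in a ring. Going by the values given here, no pair of measured compounds shows this change, so nothing measured here indicates its size or direction. The expected step is a 2.1-fold higher number from compound 1 to compound 4 (0.32 log units; beyond the scatter) in this assay, toward a weaker inhibitor. Compound 4 is accordingly estimated at 6000 nM, within 1800 nM to 20000 nM.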

Compound 4, half-maximal inhibitory concentration: 5940 nM
Beside the measured number, compound 4's estimate is 1.0-fold (0.00 log units) above it; the measured number falls inside the stated range.
By their numbers in this assay, from the lowest: compound 1; then compound 4; then compounds 2 and 3 (each within the scatter of the next).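

Going by these compounds alone, this is the first single-place comparison at the amine nitrogen in a ring: replacing 2-chlorobenzyl with the sulfur- and nitrogen-bearing group of compound 4 gives a 2.0-fold higher number from compound 1 to compound 4 (0.31 log units; beyond the scatter) in this assay, a modest change. The position therefore accepts a group without the benzyl link at only this modest cost. No available data bear on the origin of this step. Still open, as far as these compounds go, is how an unsubstituted benzyl, an acetyl or a urea on this nitrogen would compare with compound 1.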